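The source may hold more compounds than are shown below. What is called first, only, known or untested is meant among the compounds shown, and "the series" means these compounds.

Measured so far:
compound 1 `CCCn1c(=O)[nH]c2nc(-c3ccc(S(=O)(=O)N(C)C)cc3)[nH]c2c1=O` — in an assay on CHO cells for displacement of a labelled ligand from adenosine receptor A2b (Homo sapiens), read by scintillation counting, with a stated time of 75 min, in the presence of a further agent that is not named here (on this read-out lower numbers stand for stronger inhibition and higher numbers for weaker inhibition), compound 1 gives 18.6 nM
compound 2 `CCCn1c(=O)[nH]c2nc(-c3ccc(S(=O)(=O)N4CCN(c5cccc(Cl)c5)CC4)cc3)[nH]c2c1=O` — in this assay compound 2 gives 0.342 nM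
compound 3 `CCCn1c(=O)[nH]c2nc(-c3ccc(S(=O)(=O)N4CCN(c5ccccc5)C(C)C4)cc3)[nH]c2c1=O` — in this assay compound 3 gives 7.15 nM

All three compounds share the same core and differ only in the group attached to the sulfonyl. On the numbers shown, compound 2 stands lowest, and in this assay compound 2 gives 0.342 nM. Its nearest neighbour is compound 3, which gives 7.15 nM, a gap beyond the usual scatter; the furthest is compound 1, which gives 18.6 nM, also beyond the scatter. Compound 2 is therefore the strongest binder of the three.

The next compound, compound 4 `CCCn1c(=O)[nH]c2nc(-c3ccc(S(=O)(=O)N4CCN(Cc5ccc(Br)c(F)c5)CC4)cc3)[nH]c2c1=O`, keeps the core and the ring with two nitrogens but changes the group on the amine nitrogen: 4-bromo-3-fluorobenzyl in place of 3-chlorophenyl on an amine nitrogen in a ring. Within the data shown here, no measured pair shows this kind of change, so its effect cannot be read from the data. Some loss of binding is expected, since both other variations of this group in compound 3 and compound 1 gave higher numbers; the step of a 5.8-fold higher number from compound 2 to compound 4 (0.77 log units; beyond the scatter) is expected to be modest but beyond the scatter. Compound 4 is estimated at 2 nM, between 0.3 nM and 15 nM.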

Compound 4, inhibition constant: 0.473 nM
Compound 4: middle estimate off by 4.2-fold (0.63 log units), on the high side; the range from low to high includes it.
By their numbers in this assay, from the lowest: compounds 2 and 4 (each within the scatter of the next); then compound 3; then compound 1.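

In this assay, 4-bromo-3-fluorobenzyl in place of 3-chlorophenyl on the amine nitrogen in the ring gives a 1.4-fold higher number from compound 2 to compound 4 (0.14 log units; within the scatter), so binding is not told apart by this swap. Among these compounds, this is the first direct reading of a single change at this position, and it shows that a group of 9 heavy atoms with two halogens can stand there in place of one of 7 heavy atoms with a single chlorine, with no loss beyond the scatter. Nothing measured here explains why these two groups give such close numbers.

This single pair cannot show whether the halogens matter, which a plain benzyl group would help to test. It also leaves open how a longer chain, such as phenylethyl, or a carboxylic acid on the aromatic ring would fare at this position.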